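The source may hold more compounds than are shown below. What is called first, only, known or untested is meant among the compounds shown, and "the series" means these compounds.

Measured compounds:
compound 1, `O=C(CC1c2ccccc2N=C(SCCCCCN2CCCC2)N1c1ccc(-c2ccc(F)cc2)cc1)NCc1ccc(F)cc1`, 19800 nM
compound 2, `CN(C)CCCCCSC1=Nc2ccccc2C(CC(=O)NCc2ccc(F)cc2)N1c1ccc(-c2ccccc2)cc1`, 6100 nM

Among the compounds with values here, compound 2 has the lowest of the two numbers measured so far in an assay on cells for inhibition of Voltage-dependent T-type calcium channel subunit alpha-1I (Homo sapiens), read by patch clamp; on this read-out higher numbers stand for weaker inhibition and lower numbers for stronger inhibition; compound 1 gives a higher number, and the gap between them is beyond the scatter. Compound 3, `CN(C)CCCCCSC1=Nc2ccccc2C(CC(=O)NCc2ccc(F)cc2)N1c1ccc(-c2ccc(F)cc2)cc1`, is not yet measured. It differs from compound 2 by fluoro in place of hydrogen on an aromatic carbon, placed para to a large group; one bond further out this reads as phenyl to 4-fluorophenyl. Within the data shown here, with no measured pair showing this change alone, the expected step of a 1.0-fold lower number from compound 2 to compound 3 (0.01 log units; within the scatter) is small, with no direction beyond the scatter. Compound 3 is estimated at 6000 nM, expected between 2500 nM and 15000 nM.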

Compound 3, half-maximal inhibitory concentration: 960 nM
Compound 3: the middle estimate sits 6.3-fold (0.80 log units) above what was measured, outside the stated range (below it).
By their numbers in this assay, from the lowest: compound 3; then compound 2; then compound 1.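

In this assay, a single fluoro on this aromatic carbon, para to a large group, is far from a silent change: phenyl to 4-fluorophenyl gives a 6.4-fold lower number from compound 2 to compound 3 (0.80 log units; beyond the scatter). With 4-fluorophenyl kept, the amine at the chain end also matters, as dimethylamino in place of pyrrolidin-1-yl gives a 21-fold lower number from compound 1 to compound 3 (1.31 log units; beyond the scatter). No measurement at hand explains either step.

Open, from the compounds shown here alone, is whether chloro or methoxy on the same carbon would act like fluoro. Also open, going by these compounds, is how a piperidine at the chain end, or a longer chain, would compare.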